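A few compounds are considered here, and "the series" means these few. Any claim that something is new, unique, unknown or untested is made for them only; others in the source may bear on it.

Going by the values given here, in a functional assay on MOLT-4 cells (Homo sapiens) for inhibition (a higher number here means a weaker inhibitor, a lower number a stronger inhibitor), compound 1 (`O=C1CCCCC/C1=C\c1cccc(F)c1`) gives 482000 nM and compound 2 (`Cc1cccc(/C=C2\CCCCCC2=O)c1`) gives 228000 nM, so compound 2 holds the lower of the two numbers measured so far. Compound 3 (`COc1cccc(/C=C2\CCCCCC2=O)c1`) takes methoxy in place of methyl on an aromatic carbon, meta to a group of 9 heavy atoms: methoxy in place of methyl on an aromatic carbon. Among the compounds with values here, only one measured step bears on this change. It is a 2.1-fold lower number from compound 1 to compound 2 (0.33 log units; beyond the scatter), a modest move that swaps methyl in place of fluoro on an aromatic carbon. That single step sets a rough size for such swaps but gives no direction for methoxy. A small step in either direction is therefore expected, possibly none beyond the scatter. The expected change is a 1.1-fold higher number from compound 2 to compound 3 (0.04 log units; within the scatter). Compound 3 is estimated at 250000 nM, with an expected range of 120000 nM to 480000 nM.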

Compound 3, half-maximal inhibitory concentration: 170000 nM
Beside the measured number, compound 3's estimate is 1.5-fold (0.17 log units) above it; measured number inside the range.
By their numbers in this assay, from the lowest: compounds 3 and 2 (each within the scatter of the next); then compound 1.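

At this position, on an aromatic carbon meta to a group of 9 heavy atoms, methoxy in place of methyl gives a 1.3-fold lower number from compound 2 to compound 3 (0.13 log units; within the scatter) in this assay, so the two groups cannot be told apart here. Methoxy in place of fluoro gives a 2.8-fold lower number from compound 1 to compound 3 (0.45 log units; beyond the scatter), so the move away from fluoro now appears with a second group, and compound 2 and compound 3 both stand apart from compound 1 by steps beyond the scatter. Nothing available gives a reason for either step.

Still open, as far as these compounds go, is whether this reflects something particular to fluoro or whether a hydroxyl, an amine or a carboxylic acid at this place would fall in with methyl and methoxy. From the compounds shown here alone, whether methyl and methoxy also stay level elsewhere on the aromatic ring remains unknown.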